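Series notes: aryloxy replacement on the shared core

The source may hold more compounds than are shown below. What is called first, only, known or untested is meant among the compounds shown, and "the series" means these compounds.

Compound 3 `CC1(C)C=C(n2ccccc2=O)c2cc(OC(=O)Nc3ccccc3F)ccc2O1` gives 5.38 in a functional assay (aorta) with Rattus norvegicus as the target (a higher number here means a more potent compound, by a factor of ten per unit of this negative logarithm, a lower number a less potent compound), the lowest of the three numbers measured. For the measured compounds named here, compound 1 `CC1(C)C=C(n2ccccc2=O)c2cc(C(=O)c3cccs3)ccc2O1` gives 6.4 and compound 2 `Cc1ccccc1C(=O)c1ccc2c(c1)C(n1ccccc1=O)=CC(C)(C)O2` gives 6.83, the step of a number 0.43 log units higher from compound 1 to compound 2 (beyond the scatter) being the only one measured between neighbours. Compound 4 `CC1(C)C=C(n2ccccc2=O)c2cc(OS(=O)(=O)F)ccc2O1` differs from compound 3 as follows: fluorosulfonyl in place of (2-fluorophenyl)carbamoyl on an oxygen on an aromatic ring. Going by the values given here, that measured step concerns a group on a carbonyl carbon and does not touch the oxygen on the aromatic ring, so no measured step bears on this change and its direction is unknown here. The expectation for compound 4 is therefore near compound 3, with a step of a number 0.12 log units higher from compound 3 to compound 4 (within the scatter) estimated inside the scatter. In this assay compound 4 is estimated at 5.5, within 4.7 to 6.3.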

Compound 4, logarithm of the reciprocal of the active concentration, log(1/C): 7.95
Beside the measured number, compound 4's estimate is 2.45 log units below it; measured number outside the range, above it.
By their numbers in this assay, from the lowest: compound 3; then compound 1; then compound 2; then compound 4.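

In this assay the group on an oxygen on an aromatic ring proves decisive for this series, with fluorosulfonyl in place of (2-fluorophenyl)carbamoyl giving a number 2.57 log units higher from compound 3 to compound 4 (beyond the scatter) on the shared core. The (fluorosulfonyl)oxy group on the aromatic carbon also outdoes both carbonyl-linked groups, with a number 1.12 log units higher from compound 2 to compound 4 (beyond the scatter) and a number 1.55 log units higher from compound 1 to compound 4 (beyond the scatter) placing compound 4 highest of the four. No evidence is available to explain these steps.

The compounds shown leave open how a methanesulfonyl or acetyl group on the same oxygen would compare with fluorosulfonyl.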